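This account rests on a few compounds, and the source may have more. Where it says the series, first, only, none or still open, it means among the compounds named here.

In an ADME assay on Vero cells (Chlorocebus sabaeus) for cytotoxicity, read by MTT assay, with a stated time of 72 h (a lower number here means that less compound is tolerated, a higher number that more compound is tolerated), three compounds built on one shared core have been measured. Compound 1 `COc1c(N2C[C@H]3CCCN(Cc4cn(CCCN5C(=O)C(=O)c6cc(F)ccc65)nn4)[C@H]3C2)c(F)cc2c(=O)c(C(=O)O)cn(C3CC3)c12` gives 16 ug/mL. Compound 2 `CCO/N=C1/C(=O)N(CCCn2cc(CN3CCC[C@@H]4CN(c5c(F)cc6c(=O)c(C(=O)O)cn(C7CC7)c6c5OC)C[C@@H]43)nn2)c2ccc(F)cc21` gives 4 ug/mL. Compound 3 `COc1c(N2C[C@H]3CCCN(Cc4cn(CCCN5C(=O)C(=O)c6ccccc65)nn4)[C@H]3C2)c(F)cc2c(=O)c(C(=O)O)cn(C3CC3)c12` gives 16 ug/mL, level with compound 1 within the scatter; together they are the highest numbers of the three, and compound 2 sits beyond the scatter below them. Going by the values given here, the only single-point step measured so far, no change at the digits printed from compound 1 to compound 3 (within the scatter), left the number unchanged. Compound 4 `COc1c(N2C[C@H]3CCCN(Cc4cn(CCCN5C(=O)C(=O)c6cc(C)ccc65)nn4)[C@H]3C2)c(F)cc2c(=O)c(C(=O)O)cn(C3CC3)c12` differs from compound 3 by methyl in place of hydrogen on an aromatic carbon, on the same six-membered ring of the fused system. Since that one bearing step was flat, a step of the same kind, no change at the digits printed from compound 3 to compound 4 (within the scatter), is expected: no change beyond the scatter. Compound 4 is therefore estimated at 16 ug/mL, within a range from 8 ug/mL to 32 ug/mL.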

Compound 4, half-maximal cytotoxic concentration: 32 ug/mL
Beside the measured number, compound 4's estimate is 2.0-fold (0.30 log units) below it, within the range that was stated.
By their numbers in this assay, from the lowest: compound 2; then compounds 1, 3 and 4 (each within the scatter of the next).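

In this assay, the same ring position has now carried hydrogen, fluoro and methyl, and swapping in methyl stays within the scatter against hydrogen (a 2.0-fold higher number from compound 3 to compound 4 (0.30 log units; within the scatter)) and against fluoro (a 2.0-fold higher number from compound 1 to compound 4 (0.30 log units; within the scatter)). A group with one heavy carbon atom therefore gives a number that cannot be told apart from those of the two smaller substituents. Nothing available explains why this position responds so little. Going by these compounds, it remains open whether an amine, a carboxylic acid or a longer carbon chain here would move the number beyond the scatter.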